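Thiazole in Place of Oxadiazole on the Shared Core

The compounds below may be only part of what the source reports. "The series", "measured", "known", "first", "only" and "open" are said of these compounds alone.

Compound 1 `CCc1c(OC)nc2nc(-c3nnc(C)o3)cn2c1C` holds the lowest number among those shown in a functional assay on the whole organism with Rattus norvegicus as the target (a higher number here means that more compound is needed for the effect, a lower number that less compound is needed), where compound 1 gives 2 mg/kg. Compound 3 `CCc1c(SC)nc2nc(-c3nnc(C)o3)cn2c1C` gives 5 mg/kg in this assay. The step is a 2.5-fold higher number from compound 1 to compound 3 (0.40 log units; beyond the scatter). Compound 2 `C/C=C/c1c(OC)nc2nc(-c3nnc(C)o3)cn2c1C` reaches only a limit of this assay, > 50 mg/kg. That change is recorded as an at least 25-fold higher number from compound 1 to compound 2 (1.39 log units; beyond the scatter). Compound 4 `CCc1csc(-c2cn3c(C)c(CC)c(OC)nc3n2)n1` differs from compound 1 by 4-ethyl-1,3-thiazol-2-yl in place of 5-methyl-1,3,4-oxadiazol-2-yl on an aromatic carbon. Among the compounds with values here, neither measured step touches this part of the core: one alters the ethyl group, the other the methoxy group, so no measured step bears directly on the change, and its size is open. Compound 4 is expected to sit somewhat higher than compound 1, estimated at 5 mg/kg, between 2 mg/kg and 15 mg/kg. This expected step is a 2.5-fold higher number from compound 1 to compound 4 (0.40 log units; beyond the scatter).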

Compound 4, minimum effective dose: 50 mg/kg
The estimate for compound 4 lay 10-fold (1.00 log units) below the measured number; measured number above the stated range.
By their numbers in this assay, from the lowest: compound 1; then compound 3; then compound 4.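

The earlier steps shown here touched only the ethyl and methoxy groups, whereas this one shows that in this assay the aromatic carbon carrying the 5-methyl-1,3,4-oxadiazol-2-yl group also responds strongly to change. Placing 4-ethyl-1,3-thiazol-2-yl there gives a 25-fold higher number from compound 1 to compound 4 (1.40 log units; beyond the scatter). Nothing shown accounts for the size of this step.

From the compounds shown here alone, the ring and its alkyl group change together, so their separate shares stay open. Going by these compounds, whether a 5-ethyl-1,3,4-oxadiazol-2-yl or a 4-methyl-1,3-thiazol-2-yl group would keep the number of compound 1 also stays open.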